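Working notes on an acrylic acid series: compound 3 to compound 4

This account rests on a few compounds, and the source may have more. Where it says the series, first, only, none or still open, it means among the compounds named here.

In a functional assay on MCF7 cells (Homo sapiens) for cytotoxicity, read by CellTiter-Glo, with a stated time of 5 days (a higher number here means a weaker inhibitor, a lower number a stronger inhibitor), compound 1 `CC/C(=C(/c1ccc(/C=C/C(=O)O)cc1)c1ccc(NS(C)(=O)=O)cc1)c1ccccc1` gives 2310 nM and compound 2 `CC/C(=C(/c1ccc(/C=C/C(=O)O)cc1)c1ccc2[nH]cnc2c1)c1ccccc1` gives 1180 nM. Compound 3 `CC/C(=C(/c1ccc(/C=C/C(=O)O)cc1)c1ccc2[nH]ncc2c1)c1ccc(Cl)cc1` gives 15 nM in this assay, the lowest of the three numbers; its distance to compound 2, the nearest, and to compound 1, the furthest, both lie beyond the usual scatter, so compound 3 stands as the strongest inhibitor measured so far. For the measured compounds named here, no pair among the measured compounds differs in one place only, so no single-change step is on record and the size of the change to the unmeasured compound has no anchor in this set.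

Compound 4 `CC/C(=C(/c1ccc(/C=C/C(=O)O)cc1)c1ccc2[nH]ncc2c1)c1cscc1C` differs from compound 3 in one place: 4-methylthiophen-3-yl in place of 4-chlorophenyl on a double-bonded chain carbon bound to a double-bonded chain carbon and a saturated chain carbon. Everything else in compound 3 is kept. Compound 4 is expected to show a modest weakening. The estimated step is a 2.3-fold higher number from compound 3 to compound 4 (0.37 log units; beyond the scatter). Compound 4 is estimated at 35 nM in this assay, with a range from 10 nM to 150 nM.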

Compound 4, half-maximal inhibitory concentration: 2 nM
Compound 4: middle estimate off by 18-fold (1.24 log units), on the high side, and the stated range ends above it.
By their numbers in this assay, from the lowest: compound 4; then compound 3; then compounds 2 and 1 (each within the scatter of the next).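

In this assay, for the compounds shown here, the place on a double-bonded chain carbon bound to a double-bonded chain carbon and a saturated chain carbon responds to the change of 4-chlorophenyl to 4-methylthiophen-3-yl, with a 7.5-fold lower number from compound 3 to compound 4 (0.88 log units; beyond the scatter), which is the only single-change step on record. At this place, then, the six-membered aromatic ring of carbon only and its chlorine are not needed for a low number, since a five-membered aromatic ring with a hetero atom and a methyl group serves better in this core. The reason for the step is not shown by any measurement at hand.

Open, as far as these compounds go, is whether the step belongs to the thiophene ring or to its methyl group; a plain thiophen-3-yl or a methylphenyl group at this place would separate the two. Also open, from the compounds shown here alone, is whether the same change carries over to the cores of compound 1 and compound 2.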